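Swapping 4-nitrophenyl for 2,4-dichlorophenyl in the series

This account rests on a few compounds, and the source may have more. Where it says the series, first, only, none or still open, it means among the compounds named here.

Measured in a functional assay on A549 cells (Homo sapiens) for cytotoxicity, read by MTT assay, with a stated time of 72 h; on this read-out higher numbers stand for weaker inhibition and lower numbers for stronger inhibition:
compound 1 `CNC(=O)c1cc(Oc2ccc(C(=O)/C=C/c3ccc([N+](=O)[O-])cc3)cc2)ccn1`: > 50000 nM
compound 2 `CNC(=O)c1cc(Oc2ccc(C(=O)/C=C/c3ccc(F)cc3Cl)cc2)ccn1`: 21100 nM
compound 3 `CNC(=O)c1cc(Oc2ccc(C(=O)/C=C/c3ccccc3)cc2)ccn1`: 5040 nM

Compound 1 is known only as a limit, not as a number: the limit of > 50000 nM in this assay, at which 1 of the 3 values shown sits. Compound 4 `CNC(=O)c1cc(Oc2ccc(C(=O)/C=C/c3ccc(Cl)cc3Cl)cc2)ccn1` is still unmeasured and differs from compound 1 as follows: 2,4-dichlorophenyl in place of 4-nitrophenyl on a double-bonded chain carbon bound to a double-bonded chain carbon. The closest measured change is an at least 2.3-fold lower number from compound 1 to compound 2 (0.37 log units; beyond the scatter), with 2-chloro-4-fluorophenyl as the entering group. Hydrogen in place of nitro gives an at least 9.9-fold lower number from compound 1 to compound 3 (0.99 log units; beyond the scatter). Phenyl in place of 2-chloro-4-fluorophenyl then gives a 4.2-fold lower number from compound 2 to compound 3 (0.62 log units; beyond the scatter). The halogen-bearing compound 2, at 21100 nM, is the best guide here. A lower number than the limit of compound 1 is therefore expected in this assay, of modest size and not reaching compound 3. The expected size is an at least 2.7-fold lower number from compound 1 to compound 4 (0.44 log units; beyond the scatter). For compound 4 the estimated value is 18000 nM, with an expected range of 7000 nM to 45000 nM.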

Compound 4, half-maximal inhibitory concentration: 9460 nM
Compound 4: the middle estimate sits 1.9-fold (0.28 log units) above what was measured; the measured number falls inside the stated range.
By their numbers in this assay, from the lowest: compounds 3 and 4 (each within the scatter of the next); then compound 2. At a limit, above all of these: compound 1.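

In this assay, within the data shown here, the identity of the halogen on the ring at this place now counts: a 2.2-fold lower number from compound 2 to compound 4 (0.35 log units; beyond the scatter), a chloro-for-fluoro change that the earlier compounds could not isolate. Against phenyl the step is a 1.9-fold higher number from compound 3 to compound 4 (0.27 log units; within the scatter), so 2,4-dichlorophenyl, unlike 2-chloro-4-fluorophenyl, does not separate from phenyl in this series. The step away from 4-nitrophenyl, an at least 5.2-fold lower number from compound 1 to compound 4 (0.72 log units; beyond the scatter), is only a bound, as it starts from a limit and not a number: the limit of > 50000 nM in this assay, at which 1 of the 4 values shown sits.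

The compounds shown leave open what each chloro contributes alone, as 2-chlorophenyl and 4-chlorophenyl are not among them. Also open, going by these compounds, is how an amine or a carboxylic acid on the phenyl ring would compare with 2,4-dichlorophenyl and phenyl on this double-bonded chain carbon.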